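Series notes: liver microsome half-life, compound 2 to compound 4

The source may hold more compounds than are shown below. What is called first, only, known or untested is meant among the compounds shown, and "the series" means these compounds.

Compound 2 `CC(C)C(Cc1nnc[nH]1)c1ccc(-c2ccc3cccc(F)c3c2)[nH]c1=O` has been run in an ADME assay on microsomes from liver (Mus musculus) for metabolic stability (on this read-out lower numbers stand for a shorter-lived compound and higher numbers for a longer-lived compound), and its reading is a limit of the assay rather than a number: compound 2 gives < 0.0667 h. Two further compounds share the core but carry other groups. Compound 1 `CCn1ncc2c(F)cc(-c3ccc(C(CC)(CC)c4nnc[nH]4)c(=O)[nH]3)cc21` also stops at a limit, and in this assay compound 1 gives > 3 h. Compound 3 `CCn1ncc2c(F)cc(-c3ccc(C(CC)(CC)c4nnc(C)[nH]4)c(=O)[nH]3)cc21` likewise stops at a limit, and in this assay compound 3 gives > 3 h. Within the data shown here, the only step between measured compounds is a step that the two limits leave unreadable from compound 1 to compound 3, a methyl in place of hydrogen on an aromatic carbon, which does not touch the part changed here. Of the three values, the limit of < 0.0667 h in this assay, at which 1 of the 3 values shown sits, and (the limit of > 3 h in this assay, at which 2 of the 3 values shown sit). Compound 4 `CC(C)C(c1noc(=O)[nH]1)c1ccc(-c2ccc3cccc(F)c3c2)[nH]c1=O` is not yet measured; it differs from compound 2 by a group of 6 heavy atoms (2 carbon, 2 nitrogen, 2 oxygen; one five-membered aromatic ring with 3 hetero atoms) in place of a group of 6 heavy atoms (3 carbon, 3 nitrogen; one five-membered aromatic ring with 3 hetero atoms), on a saturated chain carbon bound to an aromatic carbon and a saturated chain carbon. Among the measured compounds shown here, no measured step bears on this change, so no direction beyond the scatter can be read for it. Compound 2 sits at the lower limit < 0.0667 h. Compound 4 is therefore expected to remain short-lived, with the estimated step of an at least 1.1-fold higher number from compound 2 to compound 4 (0.07 log units; that floor lies within the scatter) kept small. The estimated half-life of compound 4 is 0.08 h, in a range from 0.03 h to 0.3 h.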

Compound 4, half-life: > 3 h
Compound 4 was reported as a limit (the forecaster's own chance of this, stated with the estimate: 60%); middle value at least 37-fold (1.57 log units) from the limit.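

In this assay, putting the new five-membered aromatic ring in place of (4H-1,2,4-triazol-3-yl)methyl, on a saturated chain carbon bound to an aromatic carbon and a saturated chain carbon, gives an at least 44-fold higher number from compound 2 to compound 4 (1.65 log units; beyond the scatter). Among these compounds, this is the first readable step, since the step from compound 1 to compound 3 cannot be read, and it shows that the rest of compound 2 does not by itself fix a short half-life. The step is a floor and not a full size, as both of its ends are limits of the assay: the limit of > 3 h in this assay, at which 3 of the 4 values shown sit.

The compounds shown do not separate the change of ring from the loss of the methyl link, as the two travel together in this one step. From the compounds shown here alone, how a carboxylic acid at this place would read stays open.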